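Adding an amino group to a purine-like cytotoxic core

A few compounds are considered here, and "the series" means these few. Any claim that something is new, unique, unknown or untested is made for them only; others in the source may bear on it.

Three compounds share a core in which a benzyl group carrying a chloromethyl arm is attached to a fused two-ring system. Compound 1 `ClCc1ccccc1Cn1cnc2c(Cl)nc(Cl)nc21` carries two chloro groups on the six-membered ring of that system and gives 1200 nM in a functional assay on HCT-15 cells (Homo sapiens) for cytotoxicity, read by sulforhodamine B assay, with a stated time of 48 h; a higher number here means a weaker inhibitor of growth, a lower number a stronger inhibitor of growth. Going by the values given here, compound 2 `ClCc1ccccc1Cn1cnc2c(Cl)ncnc21` keeps only one chloro group and gives 4670 nM in this assay. Compound 3 `ClCc1cccc(Cn2cnc3c(Cl)ncnc32)c1` moves the chloromethyl arm to another position of the benzyl ring and gives 4670 nM in this assay. Among the compounds with values here, compound 2 therefore stands level with compound 3, and the two together sit at the high end of the three numbers, while the only step that is beyond the scatter is a 3.9-fold higher number from compound 1 to compound 2 (0.59 log units; beyond the scatter).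

Compound 4 `Nc1nc(Cl)c2ncn(Cc3ccccc3CCl)c2n1` differs from compound 2 by amino in place of hydrogen on an aromatic carbon, at the same position where compound 1 carried its second chloro group. Within the data shown here, no measured step involves an amino group, so the only guidance is that filling this position with a chloro group shifted the number beyond the scatter. Compound 4 is therefore expected to land at 3500 nM in this assay, within a range of 900 nM to 12000 nM, and the step of a 1.3-fold lower number from compound 2 to compound 4 (0.13 log units; within the scatter) is an estimate with uncertain direction.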

Compound 4, concentration for total growth inhibition: 7410 nM
Compound 4: the middle estimate sits 2.1-fold (0.33 log units) below what was measured, and the stated range covers the measured number.
By their numbers in this assay, from the lowest: compound 1; then compounds 2, 3 and 4 (each within the scatter of the next).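

In this assay, amino on this aromatic carbon between two ring nitrogen atoms gives a 1.6-fold higher number from compound 2 to compound 4 (0.20 log units; within the scatter) and so cannot be told apart from hydrogen at this position. Set against chloro on the same carbon, the amino group gives a 6.2-fold higher number from compound 1 to compound 4 (0.79 log units; beyond the scatter) and this step, like the one from compound 1 to compound 2, lies beyond the scatter. Of the three groups now seen at this position, chloro alone gives a number that stands apart from the other two, although no evidence is available to explain this.

With only hydrogen, amino and chloro shown here, it remains open whether a bromo, methoxy or methylamino group at this position would give a number close to that of compound 1 or close to those of compound 2 and compound 4. From the compounds shown here alone, it is also open whether the amino group would give a similar result on the core of compound 3, where the chloromethyl arm sits at another position of the benzyl ring.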